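The compounds below may be only part of what the source reports. "The series", "measured", "known", "first", "only" and "open" are said of these compounds alone.

Measured compounds:
- Compound 1, `S=c1n(-c2ccccc2)c(=S)n2n1CCCC2`, in a functional assay on the whole organism for inhibition, with Scenedesmus acutus as the target (a higher number here means a weaker inhibitor, a lower number a stronger inhibitor), compound 1 gives 7940 nM.
- Compound 2, `CC(C)Oc1cc(-n2c(=S)n3n(c2=S)CCCC3)c(F)cc1Cl`, in this assay compound 2 gives 7.59 nM.

Compound 2 holds the lower of these two numbers, and so is the stronger inhibitor of the pair; its gap to compound 1 is far beyond the scatter. Compound 3, `C#CCOc1cc(-n2c(=S)n3n(c2=S)CCCC3)c(F)cc1Cl`, has not yet been measured. Its difference from compound 2 is one change: propargyl in place of isopropyl on an oxygen on an aromatic ring. For the measured compounds named here, there is no measured pair in which only this change is made, so the size of the step rests on judgement. The isopropyl and propargyl groups hold the same count of heavy atoms and sit on the same oxygen, so the expectation is a small step in this assay, if any, with a slight move toward a weaker inhibitor and nothing clearly beyond the scatter. Compound 3 is therefore expected to give about 12 nM, within a range from 4 nM to 40 nM, which would be a step of a 1.6-fold higher number from compound 2 to compound 3 (0.20 log units; within the scatter).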

Compound 3, half-maximal inhibitory concentration: 2.04 nM
The estimate for compound 3 lay 5.9-fold (0.77 log units) above the measured number, and the stated range ends above it.
By their numbers in this assay, from the lowest: compound 3; then compound 2; then compound 1.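

In this assay the change from isopropyl to propargyl on the oxygen gives a 3.7-fold lower number from compound 2 to compound 3 (0.57 log units; beyond the scatter) and so counts as a modest step beyond the scatter. This shows that the group on this oxygen still matters among groups with the same count of heavy atoms: the two differ in the triple bond that propargyl carries, and propargyl goes with the lower number here. No evidence on hand explains this difference.

Going by these compounds, whether the triple bond itself is what counts stays open, and a plain propyl or allyl group on the same oxygen would help to separate it from the chain as such. A longer chain such as butynyl, or a small methyl group, would show how much room for change this position has.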